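This account rests on a few compounds, and the source may have more. Where it says the series, first, only, none or still open, it means among the compounds named here.

Measured so far in a functional assay on MCF7 cells (Homo sapiens) for antiproliferative activity, read by MTT assay, with a stated time of 48 h; a lower number here means a stronger inhibitor, a higher number a weaker inhibitor:

- compound 1 `O=C(NS(=O)(=O)c1ccccc1)c1cccnc1Cl` gives 14000 nM
- compound 2 `O=C(NS(=O)(=O)c1ccc(Br)cc1)c1cccnc1Cl` gives 11400 nM

Compound 2 stands level with compound 1 within the scatter, and these two values are all that is available for the series. With so few compounds, no trend can be claimed.

The next compound is compound 3 `O=C(NS(=O)(=O)c1ccc(Cl)cc1)c1cccnc1Cl`, which keeps the shared core and has chloro in place of bromo on an aromatic carbon. The change lies on an aromatic carbon of a six-membered aromatic ring of carbon only, para to a large group.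

Within the data shown here, one measured step bears on this change, the bromo in place of hydrogen on an aromatic carbon: a 1.2-fold lower number from compound 1 to compound 2 (0.09 log units; within the scatter). Among the measured compounds shown here, no chloro compound has been measured yet, so this small step is the only guide. On that basis, no step beyond the scatter is expected in this assay. The expected step is a 1.1-fold higher number from compound 2 to compound 3 (0.02 log units; within the scatter). For compound 3 the estimated value is 12000 nM, with an expected range from 7000 nM to 20000 nM.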

Compound 3, half-maximal inhibitory concentration: 10200 nM
Estimate against measurement, compound 3: 1.2-fold (0.07 log units) above, and the stated range covers the measured number.
By their numbers in this assay, from the lowest: compounds 3, 2 and 1 (each within the scatter of the next).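

In this assay the exchange of bromo for chloro on this aromatic carbon, para to a large group, gives a 1.1-fold lower number from compound 2 to compound 3 (0.05 log units; within the scatter) and so does not separate the two halogens. Against hydrogen at the same place, chloro gives a 1.4-fold lower number from compound 1 to compound 3 (0.14 log units; within the scatter) as a second halogen step, which means that hydrogen, bromo and chloro now all stand level at this position, with no readable change across the three compounds. No measurement at hand accounts for this flat result.

Whether any group on this carbon can move the number beyond the scatter stays open, since the compounds shown carry only hydrogen, bromo and chloro here, and a methoxy group, an amine, a carboxylic acid or a longer chain would test the position far more widely than a swap between halogens. Among these compounds, also open is whether changes elsewhere on the shared core matter more than this position, as all three compounds keep that core unchanged and the series offers no step there to read.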